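The compounds below may be only part of what the source reports. "The series", "measured", "known", "first", "only" and "open" are said of these compounds alone.

Working notes on the series.

Compound 1 `Brc1cccc2c1nnn2CC1CCCC1` and compound 2 `Brc1cccc2c1nnn2CC1CC1` share one core and differ only in the group carried on the saturated chain carbon bound to the aromatic nitrogen. In an ADME assay on microsomes from liver (Rattus norvegicus, strain Wistar) for metabolic stability, tested at 2.5 uM (on this read-out higher numbers stand for fast clearance and lower numbers for slow clearance), compound 1 gives 14.6 mL/min/g, while compound 2 gives 0.6 mL/min/g. Among the measured compounds shown here, the single measured step, a 24-fold lower number from compound 1 to compound 2 (1.39 log units; beyond the scatter), is the only comparison available so far. For the measured compounds named here, on the two numbers seen, compound 2 stands lowest, with compound 1 as its only neighbour.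

Compound 3 `CCCn1nnc2c(Br)cccc21` is the next member. Its change from compound 2 is ethyl in place of cyclopropyl on a saturated chain carbon bound to an aromatic nitrogen. Going by the values given here, the one step that bears on it is a 24-fold lower number from compound 1 to compound 2 (1.39 log units; beyond the scatter), a large move when the ring was shrunk; the step to compound 3 removes the ring rather than shrinking it further, so no comparable basis exists for another large shift. A small step, a 1.7-fold higher number from compound 2 to compound 3 (0.22 log units; within the scatter), is expected in this assay, and the value of compound 3 is estimated at 1 mL/min/g, with a range from 0.3 mL/min/g to 4 mL/min/g.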

Compound 3, intrinsic clearance in a liver preparation (reported as CLH), per the amount of preparation that the assay uses: 0.8 mL/min/g
For compound 3 the middle estimate is 1.3-fold (0.10 log units) above the measured one; low and high end bracket the measured number.
By their numbers in this assay, from the lowest: compounds 2 and 3 (each within the scatter of the next); then compound 1.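

In the assay (this assay), opening cyclopropylmethyl to propyl on a saturated chain carbon bound to an aromatic nitrogen leaves the number within the scatter (a 1.3-fold higher number from compound 2 to compound 3 (0.12 log units; within the scatter)), so a low number at this place does not depend on the three-membered ring. The large separation from the cyclopentyl group of compound 1 is also seen with the open chain (an 18-fold lower number from compound 1 to compound 3 (1.26 log units; beyond the scatter)), which leaves compound 1 apart from both compound 2 and compound 3. No evidence is at hand that explains these numbers.

The three compounds do not locate where, from the small groups to cyclopentyl, the number climbs; a cyclobutyl group or a longer chain such as butyl would bear on this. Going by these compounds, how an amine or a hydroxyl on the chain would read here also remains open.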